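Removal of the benzyl group on the shared core

The source may report more compounds than this note shows. Statements on the series, on what has been measured and on what is new or still open speak of the compounds shown alone.

Measured so far:
compound 1 `COC(=O)c1ccc(Cn2c(C(=O)C3CCN(CCC4(c5ccc(OC)c(OC)c5)CCN(C(=O)c5cc(OC)c(OC)c(OC)c5)C4)CC3)nc3ccccc32)cc1`: 7.63 nM
compound 2 `COc1cc(C(=O)N2CCC(CCN3CCC(C(=O)c4nc5ccccc5n4Cc4ccc(F)cc4)CC3)(c3ccc(F)cc3F)C2)cc(OC)c1OC`: 6.52 nM

In a functional assay for antagonist activity at Substance-P receptor (Cavia porcellus) (on this read-out higher numbers stand for weaker inhibition and lower numbers for stronger inhibition), compound 1 gives 7.63 nM and compound 2 gives 6.52 nM; the two numbers lie within the usual scatter of each other, so neither can be set above the other. Compound 3 `COc1ccc(C2(CCN3CCC(C(=O)c4nc5ccccc5[nH]4)CC3)CCN(C(=O)c3cc(OC)c(OC)c(OC)c3)C2)cc1OC` differs from compound 1 in one place: hydrogen in place of 4-(methoxycarbonyl)benzyl on an aromatic nitrogen. Going by the values given here, no measured pair shows this change, and compound 2 also carries a benzyl group on that nitrogen, so the data do not cover its loss. A moderate weakening is expected in this assay, a 3.9-fold higher number from compound 1 to compound 3 (0.59 log units; beyond the scatter). For compound 3 the estimate is 30 nM with a range of 5 nM to 200 nM.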

Compound 3, half-maximal inhibitory concentration: 6.98 nM
For compound 3 the middle estimate is 4.3-fold (0.63 log units) above the measured one; low and high end bracket the measured number.
By their numbers in this assay, from the lowest: compounds 2, 3 and 1 (each within the scatter of the next).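

In this assay, hydrogen in place of 4-(methoxycarbonyl)benzyl on the aromatic nitrogen gives a 1.1-fold lower number from compound 1 to compound 3 (0.04 log units; within the scatter) and leaves compound 1 and compound 3 indistinguishable. At this position, the substituted benzyl group and bare hydrogen therefore read alike on the shared core of compound 1. No available data bear on the reason for this result.

Still open, on these data alone, is whether a methyl group on that nitrogen would read the same. The same applies to a carboxylic acid or an amine in place of the methoxycarbonyl group on the benzyl ring.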